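The compounds below may be only part of what the source reports. "The series", "measured", "known", "first", "only" and "open" are said of these compounds alone.

Measured so far:
Compound 1, `O=C(CSc1nc(Nc2ccccc2)c2ccccc2n1)Nc1cccc(Br)c1`: 9620 nM
Compound 2, `C=CC(=O)Nc1cccc(NC(=O)CSc2nc(Nc3ccccc3Cl)c3ccccc3n2)c1`: 20700 nM

Among the measured compounds shown here, in a functional assay on MGC-803 cells (Homo sapiens) for inhibition, read by MTT assay, with a stated time of 72 h (a higher number here means a weaker inhibitor, a lower number a stronger inhibitor), compound 2 gives 20700 nM, the higher of the two numbers known so far. Compound 1 gives 9620 nM in this assay, and the gap between the two lies beyond the usual scatter. Compound 3, `C=CC(=O)Nc1cccc(NC(=O)CSc2nc(Nc3ccc(Cl)cc3Cl)c3ccccc3n2)c1`, has not yet been measured. It differs from compound 2 in one place: chloro in place of hydrogen on an aromatic carbon. For the measured compounds named here, no measured pair shows this change, so the step is expected to stay within the scatter. Compound 3 is therefore estimated at 16000 nM, within 6000 nM to 45000 nM, an expected step of a 1.3-fold lower number from compound 2 to compound 3 (0.11 log units; within the scatter) of little size.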

Compound 3, half-maximal inhibitory concentration: 12100 nM
Compound 3: the middle estimate sits 1.3-fold (0.12 log units) above what was measured, and the stated range covers the measured number.
By their numbers in this assay, from the lowest: compounds 1, 3 and 2 (each within the scatter of the next, the first and the last beyond it).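

In this assay, among the compounds shown here, the change from 2-chlorophenyl to 2,4-dichlorophenyl gives a 1.7-fold lower number from compound 2 to compound 3 (0.23 log units; within the scatter) and is the first reading of chloro at this position, para to a large group. A chloro group can therefore sit here without a step beyond the scatter, at least in this one pair. No measurement shown here accounts for the size of this step.

Still open, from the compounds shown here alone, is whether a methoxy group, an amine or a carboxylic acid at this same position would also stay within the scatter. A single pair also leaves open whether chloro would give a similar step on a different compound.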